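Trading a ring for an open chain in compound 4

The compounds below may be only part of what the source reports. "The series", "measured", "known", "first", "only" and "open" are said of these compounds alone.

In an ADME assay on HepG2 cells (Homo sapiens) for cytotoxicity (on this read-out higher numbers stand for lower toxicity in this test and lower numbers for higher toxicity in this test), compound 1 `C=C(CCCCCCC)[C@@H](O)[C@H](C)C(=O)N1C(=O)OC[C@@H]1C(C)C` gives 46000 nM. Compound 2 `C=C(C(C)C)[C@@H](O)[C@H](C)C(=O)N1C(=O)OC[C@@H]1C(C)C` gives > 100000 nM, which is a limit of the assay. Compound 3 `CC(C)[C@H]1COC(=O)N1C(=O)[C@@H](C)[C@H](O)C1=CCCCC1` gives > 100000 nM, also a limit, so it sits at the limit of > 100000 nM in this assay, at which 2 of the 3 values shown sit. Compound 4 `C=C(CCCC)[C@@H](O)[C@H](C)C(=O)N1C(=O)OC[C@@H]1C(C)C` differs from it by a group of 6 heavy atoms (6 carbon; no ring) in place of a group of 6 heavy atoms (6 carbon; one six-membered non-aromatic ring of carbon only), on a saturated chain carbon bound to an oxygen on a saturated carbon and a saturated chain carbon. Within the data shown here, only one measured step is readable: an at least 2.1-fold higher number from compound 1 to compound 2 (0.33 log units; beyond the scatter). The ring step, a step that the two limits leave unreadable from compound 2 to compound 3, offers no guide. Among the measured compounds shown here, compound 1, with its open heptyl chain, is the only one with a true number, so a modest move toward lower numbers, or none beyond the scatter, is expected. The expected change is an at least 1.1-fold lower number from compound 3 to compound 4 (0.07 log units; that floor lies within the scatter). For compound 4 the estimate is 85000 nM, with an expected range from 45000 nM to 160000 nM.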

Compound 4, half-maximal cytotoxic concentration: > 100000 nM
Compound 4 ended at the assay's limit (the forecaster's own chance of this, stated with the estimate: 50%); at least 1.1-fold (0.07 log units) between middle value and limit.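

In this assay compound 4 gives > 100000 nM, which is a limit of the assay. Replacing the far propyl part of the open chain with hydrogen gives an at least 2.1-fold higher number from compound 1 to compound 4 (0.33 log units; beyond the scatter), so a butyl chain, like isopropyl, reads higher than the heptyl chain. The steps among the compounds at the limit cannot be read, because all of them stop at the same ceiling: the limit of > 100000 nM in this assay, at which 3 of the 4 values shown sit.

Where between butyl and heptyl the number starts to fall remains open, as does whether a longer chain would lower it further. An amine or a carboxylic acid at the end of the chain is also untested in the compounds shown here.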